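The source may hold more compounds than are shown below. What is called first, only, known or untested is meant among the compounds shown, and "the series" means these compounds.

In a functional assay on the whole organism for antagonist activity, with Rattus norvegicus as the target (a higher number here means that more compound is needed for the effect, a lower number that less compound is needed), compound 1 `c1ccc2c(c1)CC2CN1CCN(c2cccc3c2OCCO3)CC1` gives 0.67 mg/kg and sits within the scatter of compound 3 `c1ccc2c(c1)CC(CN1CCN(c3cccc4c3OCCO4)CC1)C2` at 0.55 mg/kg on these numbers. Compound 2 `c1ccc2c(c1)CC2CCCCN1CCN(c2cccc3c2OCCO3)CC1` at 1.43 mg/kg needs more compound than compound 1, and that gap lies beyond the scatter. Compound 4 `Clc1cccc2c1CC2CN1CCN(c2cccc3c2OCCO3)CC1` is the open case: it carries chloro in place of hydrogen on an aromatic carbon of the core of compound 1 chloro in place of hydrogen on an aromatic carbon with the place being ortho to a fused ring and meta to a fused ring. Within the data shown here, no measured pair shows what such a substitution does, so the expectation is weak. With compound 1 at 0.67 mg/kg as the only anchor, no step beyond the scatter is expected in this assay in either direction. The estimated change is a 1.1-fold lower number from compound 1 to compound 4 (0.05 log units; within the scatter) and it is expected to stay inside the scatter. For compound 4 the expected value is 0.6 mg/kg with an estimated range from 0.25 mg/kg to 1.4 mg/kg for now.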

Compound 4, dose for 50% inhibition: 0.8 mg/kg
Beside the measured number, compound 4's estimate is 1.3-fold (0.12 log units) below it; low and high end bracket the measured number.
By their numbers in this assay, from the lowest: compounds 3, 1, 4 and 2 (each within the scatter of the next, the first and the last beyond it).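

Chloro in place of hydrogen on an aromatic carbon gives the first step in the series that changes only one place on the core of compound 1 (a 1.2-fold higher number from compound 1 to compound 4 (0.08 log units; within the scatter)), read in this assay. Among these compounds, at this position, ortho to a fused ring and meta to a fused ring, a single chlorine therefore leaves the read-out within the scatter, something compounds 1, 2 and 3 could not show, since no pair among them differs in one place. No measurement at hand speaks to the reason for this result.

Going by these compounds, whether this position accepts other groups as well, such as methoxy, an amine or a carboxylic acid, remains open. Also open, on these data alone, is whether chloro on another aromatic carbon of the core gives a step of similar size.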